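Notes on the ataxin-2 amide series

The source may hold more compounds than are shown below. What is called first, only, known or untested is meant among the compounds shown, and "the series" means these compounds.

Compound 1 `NS(=O)(=O)c1ccc(COc2ccc(CNC(=O)[C@@H]3CCC(=O)N3Cc3ccccc3)cc2)cc1` in an assay on HEK293 cells for inhibition of Ataxin-2 (Mus musculus), read by fluorescence and Amplex Red (on this read-out lower numbers stand for stronger inhibition and higher numbers for weaker inhibition), gives > 5000 nM, which is a limit of the assay rather than a number.
Compound 2 `O=C(O)c1ccc(COc2ccc(CNC(=O)[C@@H]3CCC(=O)N3Cc3ccccc3)cc2)cc1` in this assay gives 4500 nM.

Among the measured compounds shown here, compound 2 thus holds the only actual number in this assay; the other result is a limit. The step of an at least 1.1-fold lower number from compound 1 to compound 2 (0.04 log units; that floor lies within the scatter) is small and starts from a limit (the limit of > 5000 nM in this assay, at which 1 of the 2 values shown sits). Compound 3 `O=C(O)c1ccc(COc2ccc(CNC(=O)[C@@H]3CCC(=O)N3Cc3ccc(Br)cc3)cc2)cc1` differs from compound 2 by bromo in place of hydrogen on an aromatic carbon. For the measured compounds named here, no measured step touches this position, so nothing supports a shift beyond the scatter. The step of a 1.3-fold lower number from compound 2 to compound 3 (0.11 log units; within the scatter) is expected to stay within the scatter. Compound 3 is therefore estimated at 3500 nM, in the range 1200 nM to 10000 nM.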

Compound 3, half-maximal inhibitory concentration: > 5000 nM
Compound 3 gave a limit, no number (the forecaster's own chance of this, stated with the estimate: 35%); at least 1.4-fold (0.15 log units) between middle value and limit.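

The benzyl group now has its first reading: the change from benzyl to 4-bromobenzyl gives an at least 1.1-fold higher number from compound 2 to compound 3 (0.04 log units; that floor lies within the scatter). In this assay compound 3 gives > 5000 nM, which is a limit of the assay and not a number, so bromo on this aromatic carbon brings no gain, and the size of any loss cannot be read. Little in the series can be ranked on this read-out: the limit of > 5000 nM in this assay, at which 2 of the 3 values shown sit.

Open, on these data alone, is how a chloro group, a methoxy group or an amine on this aromatic carbon would read. Also open, as far as these compounds go, is whether the unsubstituted phenyl is needed here at all.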